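Replacing the styryl arm with a dimethoxyphenyl ring in a urea series

This account rests on a few compounds, and the source may have more. Where it says the series, first, only, none or still open, it means among the compounds named here.

The series rests on a shared core carrying a cinnamate ester and an acylated or urea-linked benzylic nitrogen. Compound 1 `COC(=O)/C=C/c1cccc(N(Cc2ccc(/C=C/c3c(C)cc(C)cc3C)cc2)C(=O)C(C)C)c1` gives 149 nM in an assay on isolated protein with Bile acid receptor (Homo sapiens) as the target; a lower number here means that less compound is needed, a higher number that more compound is needed for the effect. Compound 2 `COC(=O)/C=C/c1cccc(N(Cc2ccc(/C=C/c3c(C)cc(C)cc3C)cc2)C(=O)NC(C)C)c1` gives 431 nM in this assay, the highest number of the three measured; compound 3 `COC(=O)/C=C/c1cccc(N(Cc2ccc(/C=C/c3ccc(OC)cc3)cc2)C(=O)C2CCCCC2)c1` gives 208 nM in this assay, and compound 1 stands further below compound 2 still. Going by the values given here, the only single-place step, a 2.9-fold higher number from compound 1 to compound 2 (0.46 log units; beyond the scatter), concerns the carbonyl substituent and not the arm that now changes.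

Compound 4 `COC(=O)/C=C/c1cccc(N(Cc2ccc(-c3c(OC)cccc3OC)cc2)C(=O)NC(C)C)c1` keeps the isopropylamino urea of compound 2 and differs only in the arm: 2,6-dimethoxyphenyl in place of 2-(2,4,6-trimethylphenyl)ethenyl on an aromatic carbon. Among the compounds with values here, no measured step touches this part of the molecule; compounds 1 and 3 differ in two places, so their values only show that a methoxy-bearing arm can sit in the same range as the trimethylphenyl one. With the double bond gone and the ring shortened, a modest rise in the number is expected, a 1.9-fold higher number from compound 2 to compound 4 (0.27 log units; within the scatter), and compound 4 is therefore estimated at 800 nM (range 250 nM to 2500 nM) in this assay.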

Compound 4, half-maximal effective concentration: 561 nM
For compound 4 the middle estimate is 1.4-fold (0.15 log units) above the measured one; measured number inside the range.
By their numbers in this assay, from the lowest: compounds 1 and 3 (each within the scatter of the next); then compounds 2 and 4 (each within the scatter of the next).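

Going by these compounds alone, this is the first reading at this position: on an aromatic carbon para to a large group, with the isopropylamino urea held fixed, exchanging 2-(2,4,6-trimethylphenyl)ethenyl for 2,6-dimethoxyphenyl gives a 1.3-fold higher number from compound 2 to compound 4 (0.11 log units; within the scatter) in this assay. The entering group has no double bond outside aromatic rings and brings two hydrogen-bond acceptors, yet the numbers of the two compounds cannot be told apart. No available evidence bears on the reason for this result.

From the compounds shown here alone, it remains open whether the same exchange would give a similar result with the isopropyl carbonyl group of compound 1 in place of the urea. Going by these compounds, it is equally open how the number would respond to a hydroxyl group in place of the methoxy groups, or to a carboxylic acid in place of the methyl ester.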